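Moving the Bromine Around the Ring: Compound 3

The source may report more compounds than this note shows. Statements on the series, on what has been measured and on what is new or still open speak of the compounds shown alone.

Compound 2 `COc1cc(OC)c(OC)cc1/C=C/COC(=O)/C=C/c1ccc(Br)cc1` was tested in a functional assay on the whole organism (strain Kunming) with Mus musculus as the target, with a stated time of 0.5 h, at a dose of 100 mg/kg by the intraperitoneal route (a lower number here means a stronger effect, a higher number a weaker effect of the compound at the dose given), where compound 2 gives 100%. Its nearest neighbour is compound 1 `COc1ccccc1/C=C/C(=O)OC/C=C/c1cc(OC)c(OC)cc1OC`, which in this assay gives 100%; the two stand level, as the step of no change at the digits printed from compound 1 to compound 2 (within the scatter) shows. That step swaps the whole aryl group, 4-bromophenyl in place of 2-methoxyphenyl on a double-bonded chain carbon bound to a double-bonded chain carbon, and the read-out does not move.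

Compound 3 `COc1cc(OC)c(OC)cc1/C=C/COC(=O)/C=C/c1cccc(Br)c1` has not yet been measured. It differs from compound 2 by 3-bromophenyl in place of 4-bromophenyl on a double-bonded chain carbon bound to a double-bonded chain carbon. The same atoms are present, only the bromine sits at a different position on the ring; no donor or acceptor is gained or lost.

Among the measured compounds shown here, the one measured step bears on this only loosely: a far larger change of the aryl group left the read-out unmoved, so a smaller one is not expected to move it either. The step of no change at the digits printed from compound 2 to compound 3 (within the scatter) is therefore expected to lie within the scatter. Compound 3 is estimated at 100%, between 85% and 100%.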

Compound 3, a percentage reported as activity, at one dose (the size of the read-out at that dose, not a potency): 100%
Compound 3: middle estimate and measured number agree at the digits printed, and the stated range covers the measured number.
By their numbers in this assay, from the lowest: compounds 1, 2 and 3 (each within the scatter of the next).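

In this assay the position of the bromine on the ring now gets a test of its own: the atoms stay the same and only their arrangement differs, and 3-bromophenyl in place of 4-bromophenyl gives (no change at the digits printed from compound 2 to compound 3 (within the scatter)). Set against the earlier aryl group, 3-bromophenyl in place of 2-methoxyphenyl gives (no change at the digits printed from compound 1 to compound 3 (within the scatter)), so neither of these two kinds of change at this place on the chain separates the three compounds at the single dose tested. No measurement is available that would explain this flat result.

With all three compounds level, the results leave open whether any group at this place can shift the read-out in this assay, since every aryl group shown carries only a bromine or a methoxy group and none carries an amine or a carboxylic acid. On these data alone, it also remains open whether the read-out would stay level if the ester joining the two parts of the molecule gave way to an amide or if a longer chain separated the aryl group from the carbonyl.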